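A few compounds are considered here, and "the series" means these few. Any claim that something is new, unique, unknown or untested is made for them only; others in the source may bear on it.

Of the compounds shown here, three built on one shared core have been tested in a functional assay on PC-3 cells (Homo sapiens) for antiproliferative activity, read by CCK-8 assay, with a stated time of 72 h; on this read-out higher numbers stand for weaker inhibition and lower numbers for stronger inhibition. Compound 1 `Cc1cc(Nc2cc(N3CCN(C)CC3)nc(Nc3ccc(S(N)(=O)=O)cc3)n2)n[nH]1` gives 4380 nM. Compound 2 `Cc1cc(Nc2cc(N3CCN(C)CC3)nc(Nc3ccc([N+](=O)[O-])cc3)n2)n[nH]1` gives 1090 nM. Compound 3 `COc1cccc(Nc2nc(Nc3cc(C)[nH]n3)cc(N3CCN(C)CC3)n2)c1` gives 1080 nM, the lowest of the three numbers, although its gap to compound 2 lies within the scatter, so the two cannot be ranked; only compound 1 stands clearly apart from it.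

Compound 4 `Cc1cc(Nc2cc(N3CCN(C)CC3)nc(Nc3ccc(C#N)cc3)n2)n[nH]1` is not yet measured. It differs from compound 3 in one place: 4-cyanophenyl in place of 3-methoxyphenyl on a nitrogen on an aromatic ring.

All three measured steps concern the group on that same nitrogen on an aromatic ring, so all bear on this change. Going by the values given here, there was a 4.0-fold lower number from compound 1 to compound 2 (0.60 log units; beyond the scatter) and a 4.1-fold lower number from compound 1 to compound 3 (0.61 log units; beyond the scatter), both modest, while a 1.0-fold lower number from compound 2 to compound 3 (0.00 log units; within the scatter) was no step at all. Two different aryl groups thus land at the same level, and only the sulfamoyl variant sits higher. A third aryl group, 4-cyanophenyl, is expected to land near that common level rather than to open a new gap, with no clear direction favoured. Compound 4 is therefore expected to give about 1200 nM, within a range of 450 nM to 3500 nM. The expected step is a 1.1-fold higher number from compound 3 to compound 4 (0.05 log units; within the scatter), within the scatter.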

Compound 4, half-maximal inhibitory concentration: 977 nM
For compound 4 the middle estimate is 1.2-fold (0.09 log units) above the measured one; low and high end bracket the measured number.
By their numbers in this assay, from the lowest: compounds 4, 3 and 2 (each within the scatter of the next); then compound 1.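

In this assay a third aryl group on this nitrogen lands at the level already shared by the other two, since both the step of a 1.1-fold lower number from compound 3 to compound 4 (0.04 log units; within the scatter) and the step of a 1.1-fold lower number from compound 2 to compound 4 (0.05 log units; within the scatter) stay within the scatter. Going by these compounds alone, compound 2, compound 3 and compound 4 therefore cannot be ranked, and swapping 3-methoxyphenyl for 4-cyanophenyl changes the number by no more than repeat measurements would, while compound 1, with its 4-sulfamoylphenyl group, is the one compound that goes against this shared level, as the modest step of a 4.5-fold lower number from compound 1 to compound 4 (0.65 log units; beyond the scatter) lies beyond the scatter. No measurement at hand explains either the shared level or the higher number of compound 1.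

As far as these compounds go, all four compounds carry a phenyl ring with a single added group on this nitrogen, so it remains open whether a plain phenyl, or a ring bearing an amine or a carboxylic acid, would stay at this level or move towards compound 1. Also open, from the compounds shown here alone, is whether the level holds when the groups shown sit elsewhere on the ring, as in 4-methoxyphenyl or 3-cyanophenyl.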